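The compounds below may be only part of what the source reports. "The series", "measured", "known", "first", "only" and "open" are said of these compounds alone.

Measured in an ADME assay on microsomes from liver (Homo sapiens) for metabolic stability; a lower number here means that the compound disappears faster, a higher number that the compound lasts longer:
- Compound 1 `CC(C)C(c1ncco1)c1ccc(-c2ccc3cccc(F)c3c2)[nH]c1=O`: 0.178 h
- Compound 2 `CC(C)C(Cc1nnc[nH]1)c1ccc(-c2ccc3cccc(F)c3c2)[nH]c1=O`: 0.307 h
- Compound 3 `CC(C)C(c1cnc(N)s1)c1ccc(-c2ccc3cccc(F)c3c2)[nH]c1=O`: 0.178 h

Compound 3 stands level with compound 1, and all three values lie within the scatter of one another. Compound 4 `CC(C)C(Cc1nnn[nH]1)c1ccc(-c2ccc3cccc(F)c3c2)[nH]c1=O` differs from compound 3 by one change on a saturated chain carbon bound to an aromatic carbon and a saturated chain carbon: (1H-tetrazol-5-yl)methyl in place of 2-amino-1,3-thiazol-5-yl on a saturated chain carbon bound to an aromatic carbon and a saturated chain carbon. Three measured exchanges at this place bear on it: a 1.7-fold higher number from compound 1 to compound 2 (0.24 log units; within the scatter), no change at the digits printed from compound 1 to compound 3 (within the scatter) and a 1.7-fold lower number from compound 2 to compound 3 (0.24 log units; within the scatter). None goes beyond the scatter. Of the measured groups, (4H-1,2,4-triazol-3-yl)methyl in compound 2 most resembles the entering (1H-tetrazol-5-yl)methyl, and compound 2 gives 0.307 h. Going by the values given here, no compound with the entering group has been measured yet. A small upward move in this assay is therefore expected, but nothing beyond the scatter. The expected step is a 1.6-fold higher number from compound 3 to compound 4 (0.20 log units; within the scatter). For compound 4 the estimated half-life is 0.28 h, with an expected range of 0.15 h to 0.55 h.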

Compound 4, half-life: > 3 h
Compound 4 gave a limit, no number; the forecaster's own chance of this, stated with the estimate: 3%; at least 10-fold (1.02 log units) between middle value and limit.
By their numbers in this assay, from the lowest: compounds 1, 3 and 2 (each within the scatter of the next). At a limit, above all of these: compound 4.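

In this assay, compound 4 stands at a limit of the assay and not at a number: the limit of > 3 h in this assay, at which 1 of the 4 values shown sits. This position can therefore move the half-life beyond the scatter, which no exchange among compound 1, compound 2 and compound 3 did, as shown by an at least 16-fold higher number from compound 3 to compound 4 (1.22 log units; beyond the scatter) and by an at least 16-fold higher number from compound 1 to compound 4 (1.22 log units; beyond the scatter). The tightest comparison keeps the chain and changes only the ring, 1H-tetrazol-5-yl in place of 4H-1,2,4-triazol-3-yl, and it gives an at least 9.7-fold higher number from compound 2 to compound 4 (0.98 log units; beyond the scatter), so the methyl-linked chain alone does not carry the gain.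

From the compounds shown here alone, how far the half-life of compound 4 extends past the limit stays open. Also open, going by these compounds, is whether a carboxylic acid at this place, or a longer chain bearing the 1H-tetrazol-5-yl, would hold the same gain.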